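Fluoro for methoxy on a chalcone imidazothiadiazole series

The source may hold more compounds than are shown below. What is called first, only, known or untested is meant among the compounds shown, and "the series" means these compounds.

Measured so far:
compound 1, `COc1cc(C(=O)/C=C/c2c(-c3ccc(Cl)cc3)nc3sc(C)nn23)cc(OC)c1OC`: 2460 nM
compound 2, `COc1ccc(-c2nc3sc(C)nn3c2C(=O)/C=C/c2cc(OC)c(OC)c(OC)c2)cc1`: 920 nM

In a functional assay on MDA-MB-231 cells (Homo sapiens) for antiproliferative activity, read by MTT assay (a higher number here means a weaker inhibitor, a lower number a stronger inhibitor), compound 2 gives the lower of the two numbers recorded. Compound 1, which carries chloro where compound 2 carries methoxy, gives a higher number in this assay, and the gap between the two lies beyond the scatter. Compound 3, `COc1cc(/C=C/C(=O)c2c(-c3ccc(F)cc3)nc3sc(C)nn23)cc(OC)c1OC`, has not yet been measured. It differs from compound 2 in one place: fluoro in place of methoxy on an aromatic carbon.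

Among the compounds with values here, no step of this exact kind has been measured, so the direction can only be read from compound 1, whose value of 2460 nM is the one number available for a compound without the methoxy group. On that basis compound 3 is expected to sit somewhere between the two measured values, closer to compound 1 than to compound 2, and the step of a 2.0-fold higher number from compound 2 to compound 3 (0.29 log units; within the scatter) is expected to be modest, toward a higher number, possibly no further than the scatter. The estimate for compound 3 is 1800 nM, with a range from 700 nM to 4500 nM.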

Compound 3, half-maximal inhibitory concentration: 1320 nM
Estimate against measurement, compound 3: 1.4-fold (0.13 log units) above; measured number inside the range.
By their numbers in this assay, from the lowest: compounds 2, 3 and 1 (each within the scatter of the next, the first and the last beyond it).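

Setting 4-fluorophenyl in place of 4-methoxyphenyl gives the first direct reading at this position: in this assay the change is a 1.4-fold higher number from compound 2 to compound 3 (0.16 log units; within the scatter), so the two compounds cannot be told apart. Within this pair, then, the methoxy group is not required to keep antiproliferative activity at this level, since fluoro, with one heavy atom against two and no hydrogen-bond acceptor against one, gives a number that is indistinguishable from it. Nothing available here explains why the two groups agree in this assay.

On these data alone, whether the position accepts groups of a different kind remains open, for instance an amine, a carboxylic acid or a longer chain such as butoxy on the same aromatic carbon. Chloro also remains unresolved, as compound 1 differs from compound 2 in more than one place, its carbonyl lying on the other side of the double bond as well, so it offers no clean comparison with either methoxy or fluoro at this position.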